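This account rests on a few compounds, and the source may have more. Where it says the series, first, only, none or still open, it means among the compounds named here.

Working notes on the series. Of the compounds shown here, two have been measured in a functional assay on HepG2 cells (Homo sapiens) for antiproliferative activity, with a stated time of 72 h (a lower number here means that less compound is needed, a higher number that more compound is needed for the effect), so far, and both results are limits of the assay rather than numbers. Compound 1 `COc1ccc(-c2cc(=O)c3c(OC)cc(OC)cc3[nH]2)cc1` gives > 31100 nM in this assay, which is a limit. Compound 2 `COC(=O)c1cc(=O)c2cc(NC(=O)Nc3ccc(F)c(Cl)c3)ccc2[nH]1` gives > 6350 nM in this assay, again a limit only. Among the measured compounds shown here, compound 1 and compound 2 share no single-point difference, so no step between measured compounds can be drawn; each value sits at its own limit, as in the limit of > 31100 nM in this assay, at which 1 of the 2 values shown sits, and (the limit of > 6350 nM in this assay, at which 1 of the 2 values shown sits). Compound 2 therefore stands with no measured number of its own, only a limit, and the other value shown is likewise a limit.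

The next compound, compound 3 `COC(=O)c1cc(=O)c2cc(NC(=O)Nc3ccc4c(c3)CCC4)ccc2[nH]1`, differs from compound 2 in one place: 2,3-dihydro-1H-inden-5-yl in place of 3-chloro-4-fluorophenyl on an amide-type nitrogen. Both leaving and entering groups carry no hydrogen-bond donors or acceptors and no net charge. With nothing measured on either side of this change, no step beyond the scatter is expected in this assay; the likely result is another limit. The expected step from compound 2 to compound 3 is a step that the limit leaves unreadable from compound 2 to compound 3. For compound 3 the estimate in this assay is 10000 nM, between 3000 nM and 40000 nM.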

Compound 3, half-maximal effective concentration: > 24100 nM
Compound 3: a limit, no number; the forecaster's own chance of this, stated with the estimate: 70%; middle value at least 2.4-fold (0.38 log units) from the limit.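

In this assay compound 3 gives > 24100 nM, which is a limit and not a number. Among the compounds shown here, compound 2 and compound 3 thus both rest on limits, so no step between them can be read. The compounds shown leave open whether exchanging 3-chloro-4-fluorophenyl for 2,3-dihydro-1H-inden-5-yl on the amide-type nitrogen changes the result in this assay.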